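Varying the group on the ring amine nitrogen

This account rests on a few compounds, and the source may have more. Where it says the series, first, only, none or still open, it means among the compounds named here.

Going by the values given here, compound 2 `CN1CCN(C(=S)SCc2ccc(C(=O)Nc3ccccc3N)cc2)CC1` stands highest of the two numbers so far in a functional assay on MGC-803 cells (Homo sapiens) for antiproliferative activity, read by CCK-8 assay, with a stated time of 72 h, tested at 2 uM (on this read-out lower numbers stand for a weaker effect and higher numbers for a stronger effect at the one concentration tested), where compound 2 gives 29.6%. Its nearest neighbour is compound 1 `COc1ccc(N2CCN(C(=S)SCc3ccc(C(=O)Nc4ccccc4N)cc3)CC2)cc1`, which in this assay gives 25.3%; the two values are within the scatter of each other, so neither can be called the stronger.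

The next compound, compound 3 `Nc1ccccc1NC(=O)c1ccc(CSC(=S)N2CCN(c3ncccn3)CC2)cc1`, differs from compound 2 at the same site as compound 1 does: pyrimidin-2-yl in place of methyl on an amine nitrogen in a ring.

Among the compounds with values here, the only measured step bearing on this position is the exchange of methyl for 4-methoxyphenyl, a number 4.3 percentage points higher from compound 1 to compound 2 (within the scatter). Within the data shown here, that step lay within the scatter, so the one comparison available at this site shows no effect in this assay of a larger or smaller group on the ring amine nitrogen. Among the measured compounds shown here, with no further steps to draw on, no step beyond the scatter is expected for compound 3; the estimated step is a number 1.6 percentage points lower from compound 2 to compound 3 (within the scatter).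

For compound 3 in this assay the estimate is 28%, with a range from 14% to 44%.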

Compound 3, a percentage reported as inhibition, at one concentration (the size of the read-out at that concentration, not a potency): 28.4%
The estimate for compound 3 lay 0.4 percentage points below the measured number; low and high end bracket the measured number.
By their numbers in this assay, from the lowest: compounds 1, 3 and 2 (each within the scatter of the next).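

Pyrimidin-2-yl in place of methyl on the amine nitrogen in the ring gives in this assay a number 1.2 percentage points lower from compound 2 to compound 3 (within the scatter), although the entering group brings 6 heavy atoms for 1, one six-membered aromatic ring with 2 hetero atoms and 2 hydrogen-bond acceptors, and pyrimidin-2-yl in place of 4-methoxyphenyl gives a number 3.1 percentage points higher from compound 1 to compound 3 (within the scatter). Methyl, 4-methoxyphenyl and pyrimidin-2-yl thus stand within the scatter of one another at this site, so neither a ring in place of methyl nor the exchange of one aromatic ring for the other shows an effect on this read-out in these three compounds. No evidence is at hand that would explain this lack of a step.

On these data alone, it stays open whether any group on this nitrogen can shift the number beyond the scatter, for instance a simple hydrogen, a longer chain ending in an amine, or a chain bearing a carboxylic acid. With one concentration per compound, the three values also leave open whether any of these compounds would give a stronger or weaker effect at another concentration.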